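Adding pyridin-3-yl to the chain of compound 3

A few compounds are considered here, and "the series" means these few. Any claim that something is new, unique, unknown or untested is made for them only; others in the source may bear on it.

Values in a functional assay for inhibition, with Homo sapiens as the target; a higher number here means a weaker inhibitor, a lower number a stronger inhibitor:
- compound 1 `O=C(NC[C@H](NS(=O)(=O)c1ccccc1)C(=O)O)c1cc2cc(OCC3CCNCC3)ccc2[nH]1` gives 13 nM
- compound 2 `O=C(NC[C@H](NS(=O)(=O)c1ccccc1)C(=O)O)c1cc2cc(OCCCc3c[nH]cn3)ccc2[nH]1` gives 100 nM
- compound 3 `O=C(O)CCNC(=O)c1cc2cc(OCC3CCNCC3)ccc2[nH]1` gives 1000 nM

Compound 3 has the highest number of the three, and so the weakest inhibition in this assay, at 1000 nM. The next compound to consider is compound 4 `O=C(O)CC(NC(=O)c1cc2cc(OCC3CCNCC3)ccc2[nH]1)c1cccnc1`, which differs from compound 3 as follows: pyridin-3-yl in place of hydrogen on a saturated chain carbon bound to an amide-type nitrogen and a saturated chain carbon. The pyridin-3-yl stands on a saturated chain carbon bound to an amide-type nitrogen and a saturated chain carbon.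

Among the measured compounds shown here, no measured step changes that carbon. The nearest evidence is the large step of a 77-fold higher number from compound 1 to compound 3 (1.89 log units; beyond the scatter), where hydrogen replaces (phenylsulfonyl)amino on a different chain carbon. Read in reverse, it suggests that a group on this chain can lower the number, though one pair is thin support. The modest step of a 7.7-fold higher number from compound 1 to compound 2 (0.89 log units; beyond the scatter) concerns the group on the oxygen and does not bear directly on this change.

A moderate move to a lower number is therefore expected, smaller than the step from compound 1 to compound 3. The expected step is a 10-fold lower number from compound 3 to compound 4 (1.00 log units; beyond the scatter). For compound 4 the estimated value is 100 nM, with an expected range from 25 nM to 400 nM.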

Compound 4, half-maximal inhibitory concentration: 810 nM
Compound 4: the middle estimate sits 8.1-fold (0.91 log units) below what was measured; the whole stated range lies below it.
By their numbers in this assay, from the lowest: compound 1; then compound 2; then compounds 4 and 3 (each within the scatter of the next).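

In this assay, pyridin-3-yl on the saturated chain carbon bound to an amide-type nitrogen and a saturated chain carbon gives a 1.2-fold lower number from compound 3 to compound 4 (0.09 log units; within the scatter), so this position carries a six-membered aromatic ring while compound 3 and compound 4 remain indistinguishable in this read-out. The earlier step, a 77-fold higher number from compound 1 to compound 3 (1.89 log units; beyond the scatter), was made on a different chain carbon, and it now appears that the gain it records does not extend to any group placed on this chain: at this position, pyridin-3-yl does not bring the number towards that of compound 1. No measurement at hand accounts for this result.

The compounds shown leave open whether a phenyl ring, an amine or a methyl group on this same carbon would read like pyridin-3-yl, and whether (phenylsulfonyl)amino would keep its effect if moved here. They also leave open whether pyridin-3-yl on this carbon would make any difference in a compound that already carries (phenylsulfonyl)amino on the neighbouring part of the chain.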